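Swapping the Piperazine for an Imidazole on the Benzylic Carbon

The source may report more compounds than this note shows. Statements on the series, on what has been measured and on what is new or still open speak of the compounds shown alone.

Measured compounds:
- Compound 1 `CNCCN(C)Cc1ccc(-c2ccnc3ccc(-c4cnc(OC)c(NS(=O)(=O)c5ccc(F)cc5F)c4)cc23)cc1`: 254 nM
- Compound 2 `COc1ncc(-c2ccc3nccc(-c4ccc(CN5CCCCC5)cc4)c3c2)cc1NS(=O)(=O)c1ccc(F)cc1F`: 32 nM
- Compound 3 `COc1ncc(-c2ccc3nccc(-c4ccc(CN5CCN(C)CC5)cc4)c3c2)cc1NS(=O)(=O)c1ccc(F)cc1F`: 336 nM

In a functional assay on U-87MG ATCC cells (Homo sapiens) for cytotoxicity, read by MTT assay, with a stated time of 72 h (on this read-out lower numbers stand for stronger inhibition and higher numbers for weaker inhibition), compound 3 has the highest number of the three. Compound 1 is nearest to it, and the step of a 1.3-fold higher number from compound 1 to compound 3 (0.12 log units; within the scatter) stays within the scatter. Compound 2 is furthest away, and the step of an 11-fold higher number from compound 2 to compound 3 (1.02 log units; beyond the scatter) is large.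

Compound 4 `COc1ncc(-c2ccc3nccc(-c4ccc(Cn5ccnc5)cc4)c3c2)cc1NS(=O)(=O)c1ccc(F)cc1F` differs from compound 3 in one place: 1H-imidazol-1-yl in place of 4-methylpiperazin-1-yl on a saturated chain carbon bound to an aromatic carbon. All three measured steps alter the group at this same saturated chain carbon. The step of a 7.9-fold lower number from compound 1 to compound 2 (0.90 log units; beyond the scatter) was modest, an 11-fold higher number from compound 2 to compound 3 (1.02 log units; beyond the scatter) was large, and a 1.3-fold higher number from compound 1 to compound 3 (0.12 log units; within the scatter) fell within the scatter. None of them puts an aromatic five-membered ring at this position, so the direction for compound 4 cannot be read from a matching precedent; the measured steps only show that changes here can leave the number unchanged or shift it strongly.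

Compound 4 is therefore expected to land close to compound 3, with a wide range: an estimated 300 nM between 60 nM and 1500 nM. The expected step is a 1.1-fold lower number from compound 3 to compound 4 (0.05 log units; within the scatter).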

Compound 4, half-maximal inhibitory concentration: 600 nM
The estimate for compound 4 lay 2.0-fold (0.30 log units) below the measured number; the range from low to high includes it.
By their numbers in this assay, from the lowest: compound 2; then compounds 1, 3 and 4 (each within the scatter of the next, the first and the last beyond it).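

In this assay, the only aromatic five-membered ring shown on the saturated chain carbon bound to an aromatic carbon gives a 1.8-fold higher number from compound 3 to compound 4 (0.25 log units; within the scatter), so 1H-imidazol-1-yl and 4-methylpiperazin-1-yl cannot be told apart at this position. The other two comparisons do separate the groups, with a modest step (a 2.4-fold higher number from compound 1 to compound 4 (0.37 log units; beyond the scatter)) and a large one (a 19-fold higher number from compound 2 to compound 4 (1.27 log units; beyond the scatter)), and compound 2, with piperidin-1-yl, now stands apart from all three other compounds. Nothing given here explains why these groups differ.

The compounds shown leave open whether morpholin-4-yl or pyrrolidin-1-yl on this carbon would give a number close to that of compound 2 or close to those of compound 3 and compound 4. They also leave open where a 1H-1,2,4-triazol-1-yl ring would fall.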